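From Methyl to Trifluoromethyl: Compound 3 to Compound 4

This account rests on a few compounds, and the source may have more. Where it says the series, first, only, none or still open, it means among the compounds named here.

In a functional assay on a cell-free system (Platelet, plasma, Homo sapiens) for inhibition (a higher number here means a weaker inhibitor, a lower number a stronger inhibitor), compound 1 `O=C(O)COC1CCN(CCN(C(=O)c2ccc(F)cc2)c2ccc(Cl)cc2)CC1` gives 2000 nM, compound 2 `O=C(O)COC1CCN(CCN(C(=O)c2cccc(Cl)c2)c2ccc(Cl)cc2)CC1` gives 350 nM and compound 3 `Cc1cccc(C(=O)N(CCN2CCC(OCC(=O)O)CC2)c2ccc(Cl)cc2)c1` gives 310 nM. Compound 3 stands at the low end of these numbers, yet the step of a 1.1-fold lower number from compound 2 to compound 3 (0.05 log units; within the scatter) lies within the scatter. Compound 4 `O=C(O)COC1CCN(CCN(C(=O)c2cccc(C(F)(F)F)c2)c2ccc(Cl)cc2)CC1` carries trifluoromethyl in place of methyl on an aromatic carbon. Replacing 4-fluorophenyl with 3-chlorophenyl gave a 5.7-fold lower number from compound 1 to compound 2 (0.76 log units; beyond the scatter), and replacing it with 3-methylphenyl gave a 6.5-fold lower number from compound 1 to compound 3 (0.81 log units; beyond the scatter), both modest steps beyond the scatter. Among the measured compounds shown here, exchanging chloro and methyl, the closest precedent, changed nothing measurable, so little change is expected here. The expected step is a 1.0-fold lower number from compound 3 to compound 4 (0.01 log units; within the scatter), which stays within the scatter. Compound 4 is expected at 300 nM, with an estimated range of 120 nM to 750 nM.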

Compound 4, half-maximal inhibitory concentration: > 10000 nM
Compound 4: no number, only a limit; the forecaster's own chance of this, stated with the estimate: 3%; at least 33-fold (1.52 log units) between middle value and limit.
By their numbers in this assay, from the lowest: compounds 3 and 2 (each within the scatter of the next); then compound 1. At a limit, above all of these: compound 4.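

In this assay compound 4 gives only a limit, not a number: the limit of > 10000 nM in this assay, at which 1 of the 4 values shown sits. Methyl and chloro at this place on the ring were within the scatter of each other, yet trifluoromethyl brings an at least 32-fold higher number from compound 3 to compound 4 (1.50 log units; beyond the scatter) and an at least 28-fold higher number from compound 2 to compound 4 (1.45 log units; beyond the scatter), so the position does not accept every group alike. The change also leaves this compound behind the 4-fluorophenyl one, with an at least 5.0-fold higher number from compound 1 to compound 4 (0.69 log units; beyond the scatter).

On these data alone, how far past its limit compound 4 lies stays open. So does whether ethyl, methoxy or a nitrile at this place would behave like methyl or like trifluoromethyl.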